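Cytotoxicity in MT4 cells: methoxy for chloro on the anilide

The compounds below may be only part of what the source reports. "The series", "measured", "known", "first", "only" and "open" are said of these compounds alone.

The series shares one core, carried in compound 1 `COc1cc2nc(SCC(=O)Nc3cc([N+](=O)[O-])ccc3F)nc(Nc3c(Cl)cc(/C=C/C#N)cc3Cl)c2cc1OC`, compound 2 `COc1cc2nc([S+]([O-])CC(=O)Nc3ccc(F)cc3)nc(Nc3c(C)cc(/C=C/C#N)cc3C)c2cc1OC` and compound 3 `COc1cc2nc([S+]([O-])CC(=O)Nc3cccc(Cl)c3)nc(Nc3c(Cl)cc(/C=C/C#N)cc3Cl)c2cc1OC`, and varied at the anilide ring and at the sulfur linker. In an ADME assay on MT4 cells (Homo sapiens) for cytotoxicity, read by MTT assay, with a stated time of 5 days (a higher number here means that more compound is tolerated, a lower number that less compound is tolerated), compound 1 gives only a limit, > 199000 nM. One of the three values shown sits at that limit (the limit of > 199000 nM in this assay, at which 1 of the 3 values shown sits). In this assay compound 2 gives 27400 nM, and compound 3 gives 68900 nM, which is the higher of the two numbers, with compound 2 lying beyond the scatter below it.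

Compound 4 `COc1cccc(NC(=O)C[S+]([O-])c2nc(Nc3c(Cl)cc(/C=C/C#N)cc3Cl)c3cc(OC)c(OC)cc3n2)c1` is not yet measured. It differs from compound 3 only at the anilide ring (methoxy in place of chloro on an aromatic carbon), with methoxy in place of chloro on an aromatic carbon. Among the compounds with values here, no measured pair in this set separates that single change, so no step can be read directly; the two numbers at hand lie within a narrow band, and the change is expected to move the read-out little, if at all beyond the scatter.

For compound 4 in this assay the expected value is 60000 nM, within 25000 nM to 150000 nM, which means an expected step of a 1.1-fold lower number from compound 3 to compound 4 (0.06 log units; within the scatter).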

Compound 4, half-maximal cytotoxic concentration: >= 167000 nM
Compound 4: no number, only a limit; the forecaster's own chance of this, stated with the estimate: 15%; middle value at least 2.7-fold (0.44 log units) away from the limit.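

Within the data shown here, the 3-chlorophenyl to 3-methoxyphenyl change gives the first step that can be read at a single place, and in this assay it is not silent: an at least 2.4-fold higher number from compound 3 to compound 4 (0.38 log units; beyond the scatter). The aromatic carbon meta to a large group on the anilide ring therefore bears on how much compound is tolerated, at least with the oxidised sulfur linker and dichloro-substituted aniline of compound 3. Compound 4 gives only a limit, so the step has a lower bound and no measured size: the limit of >= 167000 nM in this assay, at which 1 of the 4 values shown sits.

As far as these compounds go, whether the shift follows the entry of methoxy or the departure of chloro stays open, as does the outcome with an amine or a carboxylic acid on the same carbon, or with methoxy on the dimethyl-substituted aniline of compound 2. Compound 1 and compound 2 each differ from compound 3 and compound 4 in more than one place, so no further steps can be read from them.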